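The source may report more compounds than this note shows. Statements on the series, on what has been measured and on what is new or still open speak of the compounds shown alone.

Measured so far:
compound 1 `CNC(=O)c1cc(Oc2ccc3nc(NC(=O)Nc4ccc(Cl)cc4Cl)sc3c2)ccn1`, 91.7%
compound 2 `CNC(=O)c1cc(Oc2ccc3nc(NC(=O)Nc4ccc(Br)cc4)sc3c2)ccn1`, 69.2%
compound 3 `CNC(=O)c1cc(Oc2ccc3nc(NC(=O)Nc4cc(C(F)(F)F)cc(C(F)(F)F)c4)sc3c2)ccn1`, 96.3%

In a functional assay on SK-BR-3 cells (Homo sapiens) for inhibition, read by MTT assay, with a stated time of 2 days, tested at 100 uM (a lower number here means less inhibition of growth, a higher number more inhibition of growth at the concentration tested), compound 2 stands lowest of the three, beyond the scatter from both others. Going by the values given here, the only single-place step among the measured compounds is a number 22.5 percentage points lower from compound 1 to compound 2 (beyond the scatter). Compound 3 differs from compound 2 in more than one place, so only its value can be set beside that of compound 2.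

Compound 4 `CNC(=O)c1cc(Oc2ccc3nc(NC(=O)c4cc(Cl)cc(Cl)c4)sc3c2)ccn1` differs from compound 2 by 3,5-dichlorophenyl in place of (4-bromophenyl)amino on a carbonyl carbon. The step of a number 22.5 percentage points lower from compound 1 to compound 2 (beyond the scatter) bears on the aryl exchange: bromophenyl in place of dichlorophenyl lowered inhibition, so the reverse direction here may raise it. Among the compounds with values here, no measured step covers the loss of the amino link, which adds uncertainty. A rise in this assay is expected, of a number 10.8 percentage points higher from compound 2 to compound 4 (beyond the scatter). Compound 4 is estimated at 80%, within 58% to 96%.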

Compound 4, percent growth inhibition at one concentration: 84.3%
The estimate for compound 4 lay 4.3 percentage points below the measured number, and the stated range covers the measured number.
By their numbers in this assay, from the lowest: compound 2; then compounds 4, 1 and 3 (each within the scatter of the next, the first and the last beyond it).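

On a carbonyl carbon, 3,5-dichlorophenyl in place of (4-bromophenyl)amino gives, in this assay, a number 15.1 percentage points higher from compound 2 to compound 4 (beyond the scatter). With 3,5-dichlorophenyl in place of (2,4-dichlorophenyl)amino, the step is a number 7.4 percentage points lower from compound 1 to compound 4 (within the scatter), so an aryl group on the carbonyl carbon without the amino link can match the inhibition of compound 1 in this series. No measurement at hand accounts for either step.

The steps change the amino link and the halogen pattern together, and their separate contributions remain unresolved. Going by these compounds, whether a morpholine or a carboxylic acid on this carbonyl carbon would retain inhibition also remains open.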